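Permeability of a Quinoline-Like Series: Predicting Compound 4

This account rests on a few compounds, and the source may have more. Where it says the series, first, only, none or still open, it means among the compounds named here.

Measured compounds:
compound 1, `c1ccc(Oc2ccc3c(NCCCNCc4ccco4)ccnc3c2)cc1`: 317 10^-6 cm/s
compound 2, `COc1cccc(CNCCCNc2ccnc3cc(-c4ccc(C(F)(F)F)cc4)ccc23)c1O`: 237 10^-6 cm/s
compound 3, `COc1cccc(CNCCCNc2ccnc3cc(Oc4ccccc4)ccc23)c1O`: 317 10^-6 cm/s

In an ADME assay for permeability, using PAMPA, with a stated time of 30 min, at pH 7.4 (a lower number here means that the compound crosses the layer more slowly, a higher number that the compound crosses the layer faster), compound 3 stands level with compound 1, and compound 2 lies within the scatter of both. The two steps into compound 3 were small: no change at the digits printed from compound 1 to compound 3 (within the scatter) and a 1.3-fold higher number from compound 2 to compound 3 (0.13 log units; within the scatter). Compound 4, `COc1cccc(CNCCCNc2ccnc3cc(Cc4ccc(F)cc4Cl)ccc23)c1O`, differs from compound 3 by 2-chloro-4-fluorobenzyl in place of phenoxy on an aromatic carbon. The step from compound 2 to compound 3, an exchange at the same aromatic carbon, is the one that bears on this change, and it stayed inside the scatter. Compound 4 is therefore expected to show no step beyond the scatter, a 1.1-fold lower number from compound 3 to compound 4 (0.05 log units; within the scatter). The estimate for compound 4 is 280 10^-6 cm/s, with a range from 170 10^-6 cm/s to 420 10^-6 cm/s.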

Compound 4, apparent permeability: 23 10^-6 cm/s
Compound 4: middle estimate off by 12-fold (1.09 log units), on the high side; the whole stated range lies above it.
By their numbers in this assay, from the lowest: compound 4; then compounds 2, 1 and 3 (each within the scatter of the next).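

At this aromatic carbon, this assay does not respond alike to every group: 2-chloro-4-fluorobenzyl in place of phenoxy gives a 14-fold lower number from compound 3 to compound 4 (1.14 log units; beyond the scatter) in the read-out, and in place of 4-(trifluoromethyl)phenyl it gives a 10-fold lower number from compound 2 to compound 4 (1.01 log units; beyond the scatter) as well. Going by these compounds alone, the earlier exchange at this carbon, between compound 2 and compound 3, stayed inside the scatter and so gave no sign of a step this large. Nothing at hand bears on the reason for the drop. The compounds shown leave open which part of the entering group goes with the lower number, the benzyl link, the chlorine or the fluorine. An unsubstituted benzyl or a 4-fluorobenzyl group on the same carbon would separate these.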